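Cytotoxicity notes: compound 1 to compound 4

The source may hold more compounds than are shown below. What is called first, only, known or untested is meant among the compounds shown, and "the series" means these compounds.

Three measured compounds share one core. Compound 1 `O=S(=O)(NCCNC(=S)Nc1ccc(Cl)cc1)c1ccc(-c2ccccc2OCc2ccccc2)s1` gives 12100 nM in an ADME assay on HEK-293T cells (Homo sapiens) for cytotoxicity, read by CCK-8 assay, with a stated time of 48 h; a lower number here means a stronger inhibitor, a higher number a weaker inhibitor. Compound 2 `COc1ccc(Oc2ccc(C(C)C)cc2-c2ccsc2S(=O)(=O)NCCNC(=O)Nc2cc(C(F)(F)F)cc(C(F)(F)F)c2)cc1OC` gives 12100 nM in this assay and compound 3 `O=C(NCCNS(=O)(=O)c1ccc(-c2ccccc2Oc2ccc([N+](=O)[O-])c([N+](=O)[O-])c2)s1)Nc1ccc([N+](=O)[O-])cc1` gives 16600 nM. Compound 1 stands level with compound 2, the two together the lowest numbers of the three; compound 3 sits a little higher, yet all three lie within the scatter of one another, so no order can be read. Compound 4 `COc1cccc(NC(=O)NCCNS(=O)(=O)c2ccc(-c3ccccc3OCc3ccccc3)s2)c1` remains to be measured in this assay. It differs from compound 1 in one place: a group of 11 heavy atoms (8 carbon, 1 nitrogen, 2 oxygen; one six-membered aromatic ring of carbon only) in place of a group of 10 heavy atoms (7 carbon, 1 nitrogen, 1 sulfur, 1 chlorine; one six-membered aromatic ring of carbon only), on an amine nitrogen. Within the data shown here, no measured pair differs in one place only, so no measured step guides the expectation. Because compound 2 gives 12100 nM and compound 3 gives 16600 nM, both close to compound 1 despite other differences, the step is expected to stay within the scatter, a 1.1-fold higher number from compound 1 to compound 4 (0.03 log units; within the scatter). Compound 4 is expected to give 13000 nM in this assay, within 7000 nM to 25000 nM.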

Compound 4, half-maximal inhibitory concentration: > 20000 nM
Compound 4 ended at the assay's limit (the forecaster's own chance of this, stated with the estimate: 20%); middle value at least 1.5-fold (0.18 log units) from the limit.
By their numbers in this assay, from the lowest: compounds 1, 2 and 3 (each within the scatter of the next). At a limit, above all of these: compound 4.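

In this assay, placing (3-methoxyphenyl)carbamoyl on the amine nitrogen in place of the group bearing chlorine and sulfur gives an at least 1.6-fold higher number from compound 1 to compound 4 (0.21 log units; that floor lies within the scatter). Compound 4 stands at a limit of the assay, not at a number: the limit of > 20000 nM in this assay, at which 1 of the 4 values shown sits. This one-place comparison therefore gives only a floor, so the true size of the change at this nitrogen may be small or much larger.

As far as these compounds go, it remains open whether the step follows the sulfur-to-oxygen exchange or the change in ring substituent. A carboxylic acid or a morpholine on this nitrogen also remains untested in the compounds shown.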